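A few compounds are considered here, and "the series" means these few. Any claim that something is new, unique, unknown or untested is made for them only; others in the source may bear on it.

Compound 1 `CN1CCN(C(=O)/C=C/c2ccncc2-c2ccc3ccccc3c2)CC1`: 43.6 nM
Compound 2 `CN1CCN(C(=O)/C=C/c2ccncc2-c2ccc(F)cc2)CC1`: 1210 nM

In an assay on a protein complex for inhibition of CDK8/Cyclin C (Homo sapiens), with a stated time of 1 h (a higher number here means a weaker inhibitor, a lower number a stronger inhibitor), compound 1 gives 43.6 nM, the lower of the two numbers, while compound 2 gives 1210 nM. Compound 3 `CN(C)C(=O)/C=C/c1ccncc1-c1ccc2ccccc2c1` has not yet been measured in this assay. It differs from compound 1 in one place: dimethylamino in place of 4-methylpiperazin-1-yl on a carbonyl carbon. For the measured compounds named here, no pair differing only in this way has been measured, so the effect of the change is not known. The step from compound 1 to compound 3 is expected to be small, and toward a slightly higher number at most, a 1.8-fold higher number from compound 1 to compound 3 (0.26 log units; within the scatter). Compound 3 is estimated at 80 nM in this assay, within a range of 20 nM to 320 nM.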

Compound 3, half-maximal inhibitory concentration: 30.1 nM
Estimate against measurement, compound 3: 2.7-fold (0.42 log units) above; the measured number falls inside the stated range.
By their numbers in this assay, from the lowest: compounds 3 and 1 (each within the scatter of the next); then compound 2.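

With dimethylamino in place of 4-methylpiperazin-1-yl on a carbonyl carbon, this assay shows a 1.4-fold lower number from compound 1 to compound 3 (0.16 log units; within the scatter), so the two groups cannot be told apart here. The six-membered non-aromatic ring of 4-methylpiperazin-1-yl is therefore not required for a number of this size on the core of compound 1. Nothing at hand explains this result. Going by these compounds, it remains open whether an unsubstituted amino group or a carboxylic acid on this carbonyl carbon would give a similar number, and whether dimethylamino would behave the same way on the core of compound 2.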